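Benzamide-substituted core series: aryl amide swap

A few compounds are considered here, and "the series" means these few. Any claim that something is new, unique, unknown or untested is made for them only; others in the source may bear on it.

Measured so far:
compound 1 `O=C(Nc1ccc(-n2ccc3c(NC(=O)c4ccccc4)ncnc32)cc1)c1ccc(Cl)c(Cl)c1` — 2000 nM
compound 2 `Nc1ncnc2c1ccn2-c1ccc(NC(=O)Nc2ccc(Cl)c(C(F)(F)F)c2)cc1` — 8100 nM

Two compounds of this series have a number in a functional assay on A375P cells (Homo sapiens) for antiproliferative activity, read by MTT assay, with a stated time of 24 h; a lower number here means a stronger inhibitor, a higher number a weaker inhibitor. Compound 1 `O=C(Nc1ccc(-n2ccc3c(NC(=O)c4ccccc4)ncnc32)cc1)c1ccc(Cl)c(Cl)c1` gives 2000 nM in this assay, the lower of the two numbers. Compound 2 `Nc1ncnc2c1ccn2-c1ccc(NC(=O)Nc2ccc(Cl)c(C(F)(F)F)c2)cc1` gives 8100 nM, and the gap between compound 2 and compound 1 lies beyond the scatter of the assay. The two compounds differ at more than one place, so their two values say nothing about any single change.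

Compound 3 `O=C(Nc1ccc(-n2ccc3c(NC(=O)c4ccccc4)ncnc32)cc1)c1cccc(C(F)(F)F)c1` has no number yet in this assay. It differs from compound 1 in one place: 3-(trifluoromethyl)phenyl in place of 3,4-dichlorophenyl on a carbonyl carbon. The rest of the molecule, including the benzamide on the shared core, is unchanged. Within the data shown here, no measured pair isolates this exchange, so there is no step to lean on; both groups are aryl rings without donors or acceptors, and the change is modest in size.

The step from compound 1 to compound 3 is therefore expected to be small, most likely within the scatter, with a slight lean toward a higher number: a 1.5-fold higher number from compound 1 to compound 3 (0.18 log units; within the scatter). For compound 3 the estimated value in this assay is 3000 nM, expected to fall between 1000 nM and 9000 nM.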

Compound 3, half-maximal inhibitory concentration: 4700 nM
Compound 3: the middle estimate sits 1.6-fold (0.19 log units) below what was measured; measured number inside the range.
By their numbers in this assay, from the lowest: compound 1; then compounds 3 and 2 (each within the scatter of the next).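

In this assay, the aryl group on this carbonyl carbon now has its first reading from a single change: 3-(trifluoromethyl)phenyl in place of 3,4-dichlorophenyl gives a 2.4-fold higher number from compound 1 to compound 3 (0.37 log units; beyond the scatter), a modest step. The position therefore responds to an exchange between two groups that are alike in the counted features, as each is one six-membered aromatic ring of carbon only, with no hydrogen-bond donors or acceptors and no net charge. No measurement is available that accounts for the step, so the result stands as an observation on this one pair.

On these data alone, it remains open whether a plain phenyl, a 3-chlorophenyl, a 4-chlorophenyl or a ring carrying a basic amine on this carbonyl carbon would read close to compound 1, close to compound 3 or apart from both. As far as these compounds go, it is also open whether the same exchange gives a similar step on a core without the benzamide, since compound 2 differs from compound 1 in more than one place and cannot settle that question.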